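This account rests on a few compounds, and the source may have more. Where it says the series, first, only, none or still open, it means among the compounds named here.

Measured so far in a functional assay on HT-29 cells (Homo sapiens) for antiproliferative activity, read by sulforhodamine B assay, with a stated time of 72 h; a higher number here means a weaker inhibitor, a lower number a stronger inhibitor:

Compound 1 `COc1ccc(C)cc1NC(=S)N/N=C/c1ccc2ccccc2n1` gives > 100000 nM, which is a limit of the assay rather than a number.
Compound 2 `S=C(N/N=C/c1ccc2ccccc2n1)Nc1cccc(Cl)c1` gives 48100 nM.
Compound 3 `CN(C)C(=S)N/N=C/c1cnc2ccccc2n1` gives 450 nM.

Among the numbers shown in this assay, compound 2 stands highest: the nearest measured neighbour is compound 3, whose value lies well below it, beyond the scatter. Compound 1 sits at the limit of > 100000 nM in this assay, at which 1 of the 3 values shown sits, and offers no number to compare against. Compound 4 `Cc1ccc(NC(=S)N/N=C/c2ccc3ccccc3n2)cc1` has not been measured. It differs from compound 2 in one place, (4-methylphenyl in place of 3-chlorophenyl on an amide-type nitrogen). Among the measured compounds shown here, no step between two measured compounds isolates this change, so there is no direct guide to its size or direction. Given that compound 1 and compound 2 both sit at the weak end of this assay, compound 4 is expected to stay in the same region, with a step of a 1.5-fold higher number from compound 2 to compound 4 (0.16 log units; within the scatter) that may well lie within the scatter. The estimate for compound 4 in this assay is 70000 nM, in a range from 20000 nM to 200000 nM, with a real chance that only a limit is reported.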

Compound 4, half-maximal inhibitory concentration: 85500 nM
Compound 4: middle estimate off by 1.2-fold (0.09 log units), on the low side; the range from low to high includes it.
By their numbers in this assay, from the lowest: compound 3; then compounds 2 and 4 (each within the scatter of the next). At a limit, above all of these: compound 1.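

In this assay, among the compounds shown here, the first step that can be read at this position, on an amide-type nitrogen whose other neighbour is the thiocarbonyl carbon, is a 1.8-fold higher number from compound 2 to compound 4 (0.25 log units; within the scatter), with 4-methylphenyl in place of 3-chlorophenyl. This exchange of one substituted phenyl group for another therefore gives compound 2 and compound 4 values that cannot be told apart from repeat scatter. Compound 1 is a limit and not a number, so no step involving it can be read: the limit of > 100000 nM in this assay, at which 1 of the 4 values shown sits.

On these data alone, it remains open whether a morpholine or a pyridine ring at this nitrogen, on the core of compound 2, would move the number beyond the scatter. Compound 3 differs in both its core and the group on that nitrogen, so its 450 nM cannot be assigned to either change.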